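The compounds below may be only part of what the source reports. "The series", "measured", "known", "first", "only" and "open" are said of these compounds alone.

Measured compounds:
- compound 1 `COc1ccc(-c2cc(/C=C/C(=O)c3ccc(N)cc3)[nH]n2)cc1`: -12%
- compound 2 `COc1ccc(C(=O)/C=C/c2cc(-c3cc(OC)c(OC)c(OC)c3)n[nH]2)cc1`: 3%
- compound 3 `COc1cc(-c2cc(/C=C/C(=O)c3ccc(F)c(F)c3)[nH]n2)cc(OC)c1OC`: 11%

In a functional assay on SR cells (Homo sapiens) for cytotoxicity, read by sulforhodamine B assay, with a stated time of 48 h, tested at 10 uM (on this read-out lower numbers stand for a stronger effect and higher numbers for a weaker effect at the one concentration tested), compound 1 gives the lowest of the three numbers, with compound 2 nearest and compound 3 furthest, both beyond the scatter. Compound 4 `COc1ccc(-c2cc(/C=C/C(=O)c3ccc(N)cc3)[nH]n2)cc1OC` has not yet been measured. It differs from compound 1 in one place: methoxy in place of hydrogen on an aromatic carbon, on an aromatic carbon of a six-membered aromatic ring of carbon only, ortho to a methoxy group and meta to a large group.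

Among the compounds with values here, the only measured step between compounds that differ in one place is a number 8 percentage points higher from compound 2 to compound 3 (within the scatter), and it concerns the aryl on the carbonyl carbon, not the ring changed here, so it does not bear directly on this change. Within the data shown here, compounds 2 and 3 carry three methoxy groups on the ring attached to the shared core and give numbers higher than compound 1, but each also differs from compound 1 elsewhere, so no step isolates the added methoxy. With nothing directly bearing on it, the expected step is a number 4 percentage points higher from compound 1 to compound 4 (within the scatter), none beyond the scatter. Compound 4 is therefore estimated at -8%, in a range from -25% to 12%.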

Compound 4, a percentage reported as activity, at one concentration (the size of the read-out at that concentration, not a potency): -13%
Compound 4: middle estimate off by 5 percentage points, on the high side; the range from low to high includes it.
By their numbers in this assay, from the lowest: compounds 4 and 1 (each within the scatter of the next); then compounds 2 and 3 (each within the scatter of the next).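

In this assay there is a number 1 percentage points lower from compound 1 to compound 4 (within the scatter) when methoxy takes the place of hydrogen on an aromatic carbon, ortho to a methoxy group and meta to a large group. This is the first step shown that isolates a change on this ring, and it shows that this position takes a methoxy group while compound 4 stays within the scatter of compound 1. Nothing available accounts for this result.

The compounds shown leave open whether a different group at this place, such as ethoxy, hydroxyl or an amine, would give a similar number. They also leave open what happens when the amino group on the aryl attached to the carbonyl carbon gives way to another group, such as a nitrile, with this ring held constant.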